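The source may report more compounds than this note shows. Statements on the series, on what has been measured and on what is new or still open speak of the compounds shown alone.

Measured so far:
Compound 1 `CCO[C@H](c1ccc(O[C@@H](CO)[C@@H](O)c2ccc(O)c(OC)c2)c(OC)c1)[C@H](CO)c1ccc(O)c(OC)c1`: 7900 nM
Compound 2 `CCO[C@H](c1ccc(O[C@@H](CO)[C@@H](OC)c2ccc(O)c(OC)c2)c(OC)c1)[C@H](CO)c1ccc(O)c(OC)c1`: 6300 nM
Compound 3 `COc1cc([C@H](OC)[C@@H](CO)Oc2ccc([C@@H](O)[C@H](O)CO)cc2OC)ccc1O`: 10800 nM

All three were tested in a functional assay, with a stated time of 30 min; on this read-out lower numbers stand for stronger inhibition and higher numbers for weaker inhibition. Compound 1 gives 7900 nM, which is the second highest of the three numbers, although every gap among them is small. The nearest neighbour is compound 2: a 1.3-fold lower number from compound 1 to compound 2 (0.10 log units; within the scatter). The furthest is compound 3, whose value of 10800 nM still lies within the scatter of the value of compound 1, so the three compounds cannot be told apart on this read-out.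

The next compound, compound 4 `CCO[C@H](c1ccc(O[C@@H](CO)[C@@H](O)c2ccc(O)c(OC)c2)c(OC)c1)[C@@H](CO)c1ccc(O)c(OC)c1`, keeps every atom and bond of compound 1: the two compounds have the same atoms and bonds and differ only in configuration as drawn: 1 of 4 stereo elements differ; a stereocentre at a saturated chain carbon is drawn S in compound 1 and R in compound 4. Going by the values given here, none of the measured steps involves a change of configuration. Among the compounds with values here, the only step on record, a 1.3-fold lower number from compound 1 to compound 2 (0.10 log units; within the scatter), concerns a methyl in place of hydrogen on an oxygen and itself sits within the scatter, so nothing here shows how a flipped stereocentre on a saturated chain carbon alters this assay. With no guide in either direction, the expectation for compound 4 is a step of about no change at the digits printed from compound 1 to compound 4 (within the scatter), that is, no change beyond the scatter. Compound 4 is therefore estimated at 7900 nM, with a range of 2500 nM to 25000 nM.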

Compound 4, half-maximal inhibitory concentration: 7100 nM
Compound 4: the middle estimate sits 1.1-fold (0.05 log units) above what was measured; measured number inside the range.
By their numbers in this assay, from the lowest: compounds 2, 4, 1 and 3 (each within the scatter of the next).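

Going by these compounds alone, this is the first change of configuration on record. In this assay, turning the stereocentre at a saturated chain carbon from S to R gives a 1.1-fold lower number from compound 1 to compound 4 (0.05 log units; within the scatter). Any difference within this pair could only trace back to that one stereocentre, because the two structures offer no other variable: the fact that compounds 1 and 4 differ only in the configuration as drawn. At this position, then, the drawn configuration makes no difference that this read-out can detect, at least with the groups that compound 1 carries, and the flip joins the methyl step as a second change that leaves the number within the scatter.

The compounds shown leave open whether the other stereo elements are as silent as this one, alone or flipped together, and whether this same flip would also read as nothing with the methyl ether of compound 2 in place. They also leave open whether a more distinct group on the shared core, such as an amine or a carboxylic acid, would make this stereocentre matter in this assay.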